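This account rests on a few compounds, and the source may have more. Where it says the series, first, only, none or still open, it means among the compounds named here.

Compound 3 `C=CCc1cc(-c2cccc(OC)c2)ccc1O` sits at the edge of what a functional assay on Lewis lung carcinoma cells (Mus musculus) for antiproliferative activity, read by MTT assay, with a stated time of 24 h (a higher number here means a weaker inhibitor, a lower number a stronger inhibitor), can report: compound 3 gives only the assay limit > 100000 nM, not a measured number. Its nearest measured neighbour, compound 2 `C=CCc1cc(-c2cccc(SC)c2)ccc1O`, likewise gives only the limit > 100000 nM. The step that the two limits leave unreadable from compound 2 to compound 3 therefore cannot be read. The third measured compound, compound 1 `C=CCc1cc(-c2ccccc2C(F)(F)F)ccc1O`, gives 60300 nM in this assay, and the line the limit of > 100000 nM in this assay, at which 2 of the 3 values shown sit, marks where two of the three values rest. Compound 4 `C=CCc1cc(-c2ccccc2)ccc1O` differs from compound 3 by hydrogen in place of methoxy on an aromatic carbon. Going by the values given here, no measured step bears directly on this change, so no movement beyond the usual scatter is expected. Compound 4 is estimated at 90000 nM, between 35000 nM and 250000 nM, which would be an expected step of an at least 1.1-fold lower number from compound 3 to compound 4 (0.04 log units; that floor lies within the scatter).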

Compound 4, half-maximal inhibitory concentration: > 100000 nM
Compound 4: no number, only a limit; the forecaster's own chance of this, stated with the estimate: 55%; at least 1.1-fold (0.04 log units) between middle value and limit.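

With hydrogen at this place, compound 4 also gives only a limit in this assay, so hydrogen, methoxy and methylsulfanyl cannot be told apart and the steps among compounds 2, 3 and 4 cannot be read. Going by these compounds alone, the one readable step, with hydrogen in place of trifluoromethyl, is an at least 1.6-fold higher number from compound 1 to compound 4 (0.21 log units; that floor lies within the scatter), and that floor alone does not establish a real change. Most of the series now rests at one line: the limit of > 100000 nM in this assay, at which 3 of the 4 values shown sit.

On these data alone, whether an amine or a carboxylic acid at this place would give a measurable number remains open. As far as these compounds go, how far compound 4 lies beyond its limit also remains open.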